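Replacing a small ring on compound 1 with a larger one

The compounds below may be only part of what the source reports. "The series", "measured", "known", "first", "only" and "open" are said of these compounds alone.

Measured so far:
- compound 1 `Cc1oc(C(=O)O)cc1COc1ccc(-c2nnco2)cc1`: > 10000 nM
- compound 2 `COc1ccc(-c2ccc(OCc3cc(C(=O)NS(=O)(=O)c4ccccc4)oc3C)cc2)cc1`: 5 nM
- compound 3 `COc1ccc(-c2ccc(OCc3cc(C(=O)NS(=O)(=O)c4ccccc4)oc3C)cc2)c(C)c1`: 21 nM

Among the measured compounds shown here, in an assay on cells for displacement of a labelled ligand from prostaglandin E2 receptor EP4 subtype (Homo sapiens), read by scintillation counting (on this read-out higher numbers stand for weaker inhibition and lower numbers for stronger inhibition), compound 1 gives only a limit, > 10000 nM, so no number is known for it; it is the one value among the three that sits at the limit (the limit of > 10000 nM in this assay, at which 1 of the 3 values shown sits). Compound 2 and compound 3 share a different end group on the core and are both potent, with a 4.2-fold higher number from compound 2 to compound 3 (0.62 log units; beyond the scatter). That step concerns a methyl added on an aromatic carbon, not the change followed here, so it sets no direct expectation.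

The change to compound 4 `COc1ccc(-c2ccc(OCc3cc(C(=O)O)oc3C)cc2)nc1` is 5-methoxypyridin-2-yl in place of 1,3,4-oxadiazol-2-yl on an aromatic carbon. For the measured compounds named here, none of the measured steps covers this swap, and the end group of compound 4 differs from that of compound 2 and compound 3, so the evidence is indirect. Still, compound 4 shares with those two the motif of an aromatic ring bearing a methoxy group on the shared core, and it is expected to move off the limit: an at least 25-fold lower number from compound 1 to compound 4 (1.39 log units; beyond the scatter), with considerable uncertainty. Compound 4 is therefore estimated at 400 nM, between 40 nM and 6000 nM.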

Compound 4, inhibition constant: 1300 nM
Estimate against measurement, compound 4: 3.3-fold (0.51 log units) below; low and high end bracket the measured number.
By their numbers in this assay, from the lowest: compound 2; then compound 3; then compound 4. At a limit, above all of these: compound 1.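

At this position, on an aromatic carbon of a six-membered aromatic ring of carbon only and para to a large group, putting 5-methoxypyridin-2-yl in place of 1,3,4-oxadiazol-2-yl gives an at least 7.6-fold lower number from compound 1 to compound 4 (0.88 log units; beyond the scatter) in this assay. Among the compounds shown here, the group at this position can therefore bring a compound with the carboxylic acid end of compound 1 into the range where a number can be read, which the only earlier step, a 4.2-fold higher number from compound 2 to compound 3 (0.62 log units; beyond the scatter), could not show, since it concerns a different change. The value of compound 1 is a limit, so this step has only a lower bound and its true size is unknown: the limit of > 10000 nM in this assay, at which 1 of the 4 values shown sits.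

The swap changes the ring size and the hetero atoms in the ring and brings in a methoxy group all at once, so the compounds shown cannot say which of these accounts for the step, and a plain phenyl or pyridin-2-yl ring would help to separate them. As far as these compounds go, it also remains open whether an ethoxy group or an amine in place of the methoxy group would lower the number further or raise it.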